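Moving the carbamate-bearing pyrrolidine attachment point

The source may hold more compounds than are shown below. What is called first, only, known or untested is meant among the compounds shown, and "the series" means these compounds.

Compound 1 `CN(C)c1ccc(C(=O)N2CCC(NS(=O)(=O)c3cc(S(=O)(=O)c4ccccc4)ccc3C(F)(F)F)CC2)cc1` gives 190 nM in an assay on U2OS cells for inhibition of secreted frizzled-related protein 1 (Homo sapiens), read by a luciferase reporter, with a stated time of 18 h; on this read-out higher numbers stand for an effect only at larger amounts of compound and lower numbers for an effect already at smaller amounts.
Compound 2 `O=C(c1cccnc1)N1CCC(NS(=O)(=O)c2cc(S(=O)(=O)c3ccccc3)ccc2C(F)(F)F)CC1` gives 120 nM in this assay.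
Compound 3 `CC(C)(C)OC(=O)N1CCC[C@H]1C(=O)N1CCC(NS(=O)(=O)c2cc(S(=O)(=O)c3ccccc3)ccc2C(F)(F)F)CC1` gives 60 nM in this assay.

Compound 3 gives the lowest number of the three; the step of a 3.2-fold lower number from compound 1 to compound 3 (0.50 log units; beyond the scatter) is beyond the scatter, while a 2.0-fold lower number from compound 2 to compound 3 (0.30 log units; within the scatter) is not. Compound 4 `CC(C)(C)OC(=O)N1CC[C@@H](C(=O)N2CCC(NS(=O)(=O)c3cc(S(=O)(=O)c4ccccc4)ccc3C(F)(F)F)CC2)C1` differs from compound 3 only in 1-(tert-butoxycarbonyl)pyrrolidin-3-yl in place of 1-(tert-butoxycarbonyl)pyrrolidin-2-yl on a carbonyl carbon. Within the data shown here, no measured pair changes only the point at which the pyrrolidine ring joins the carbonyl carbon, so nothing among the steps of a 1.6-fold lower number from compound 1 to compound 2 (0.20 log units; within the scatter), a 3.2-fold lower number from compound 1 to compound 3 (0.50 log units; beyond the scatter) and a 2.0-fold lower number from compound 2 to compound 3 (0.30 log units; within the scatter) speaks to this move directly; all three show that the group on this carbonyl carbon shifts this assay only modestly. For compound 4 the expected step of a 1.3-fold higher number from compound 3 to compound 4 (0.10 log units; within the scatter) is therefore none beyond the scatter, with an estimate of 75 nM and a range from 30 nM to 190 nM.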

Compound 4, half-maximal effective concentration: 80 nM
For compound 4 the middle estimate is 1.1-fold (0.03 log units) below the measured one; low and high end bracket the measured number.
By their numbers in this assay, from the lowest: compounds 3, 4, 2 and 1 (each within the scatter of the next, the first and the last beyond it).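

Replacing 1-(tert-butoxycarbonyl)pyrrolidin-2-yl with 1-(tert-butoxycarbonyl)pyrrolidin-3-yl on the carbonyl carbon gives a 1.3-fold higher number from compound 3 to compound 4 (0.12 log units; within the scatter) in this assay, so here the point at which the ring joins the carbonyl carbon can change without a shift beyond the scatter. The new group also repeats the picture set by the 2-yl isomer: a 1.5-fold lower number from compound 2 to compound 4 (0.18 log units; within the scatter) stays within the scatter, while a 2.4-fold lower number from compound 1 to compound 4 (0.38 log units; beyond the scatter) goes beyond it. No measurement shown offers an explanation for these steps. Still open, from the compounds shown here alone, is how a free pyrrolidine amine in place of the tert-butoxycarbonyl group would read, and whether the opposite stereocentre in either ring would matter.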